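Aziridinyl quinone side chains: carbamate in place of benzyl

A few compounds are considered here, and "the series" means these few. Any claim that something is new, unique, unknown or untested is made for them only; others in the source may bear on it.

Three members of the series have been measured in a functional assay on L1210 cells (Mus musculus), with a stated time of 1 days; a higher number here means a more potent compound, by a factor of ten per unit of this negative logarithm, a lower number a less potent compound. Compound 1 `CCCC1=C(N2CC2)C(=O)C(C(COC(N)=O)OC)=C(N2CC2)C1=O` gives 5.01, compound 2 `CC1=C(N2CC2)C(=O)C(Cc2ccccc2)=C(N2CC2)C1=O` gives 4.74, and compound 3 `COCCC1=C(N2CC2)C(=O)C(CCOC)=C(N2CC2)C1=O` gives 5.18. On these numbers compound 2 holds the lowest value of the three, but the gap to compound 1 lies within the scatter, so the two cannot be ranked; only the gap to compound 3 goes beyond it.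

The next compound, compound 4 `CC1=C(N2CC2)C(=O)C(C(C)COC(N)=O)=C(N2CC2)C1=O`, differs from compound 2 in a single place: a group of 7 heavy atoms (4 carbon, 1 nitrogen, 2 oxygen; no ring) in place of a group of 7 heavy atoms (7 carbon; one six-membered aromatic ring of carbon only), on a double-bonded ring carbon. Going by the values given here, no pair of measured compounds differing in one place is available, so the size of the step must be judged from the spread of the three values alone. The carbamate-bearing compound 1 sits above compound 2 in this assay by an amount within the scatter, and compound 4 carries a related side chain on the same core.

A small upward step is therefore expected, near the edge of the scatter rather than clearly beyond it: from compound 2 to compound 4 the estimate is a number 0.26 log units higher from compound 2 to compound 4 (within the scatter) in this assay. For compound 4 the expected value is 5, with a range from 4.6 to 5.4.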

Compound 4, logarithm of the reciprocal of the active concentration, log(1/C): 5.93
Compound 4: middle estimate off by 0.93 log units, on the low side; measured number outside the range, above it.
By their numbers in this assay, from the lowest: compounds 2, 1 and 3 (each within the scatter of the next, the first and the last beyond it); then compound 4.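

In this assay the position on a double-bonded ring carbon proves highly responsive to the group it carries: replacing benzyl with the open carbamate-bearing chain gives a number 1.19 log units higher from compound 2 to compound 4 (beyond the scatter), although both groups have 7 heavy atoms. Heavy-atom count alone therefore does not account for the value in this pair, while the change removes the six-membered aromatic ring and adds 1 hydrogen-bond donor and 2 hydrogen-bond acceptors, and the single step cannot assign the gain to any one of these differences. No measurement on hand explains the step.

On these data alone, it remains open whether the gain requires the carbamate itself or follows from replacing benzyl with any open chain, a question that an amine or a carboxylic acid at the same ring carbon would address. Also unresolved are the roles of the methyl branch on the side chain and of chain length, which a longer chain ending in the same carbamate, or an unbranched chain, would help separate, and whether the methyl group on the shared core affects the size of the step.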